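Amide Nitrogen Methylation on Two Related Cores

A few compounds are considered here, and "the series" means these few. Any claim that something is new, unique, unknown or untested is made for them only; others in the source may bear on it.

Compound 1 `Cc1ccc(-n2nccn2)c(C(=O)N[C@@H](C)Cn2ccc(-c3ccc(F)cn3)n2)c1` and compound 3 `Cc1ccc(-n2nccn2)c(C(=O)N(C)[C@@H](C)Cn2ccc(-c3ccc(F)cn3)n2)c1` share one core. In a functional assay on cells for antagonist activity at Orexin receptor type 2 (Homo sapiens), read by fluorescence and calcium flux, with a stated time of 30 min (a lower number here means a stronger inhibitor, a higher number a weaker inhibitor), compound 1 gives 58.4 nM and compound 3 gives 5.68 nM. The change from compound 1 to compound 3 is methyl in place of hydrogen on an amide-type nitrogen, and the step is a 10-fold lower number from compound 1 to compound 3 (1.01 log units; beyond the scatter). Compound 2 `Cc1ccc(-n2nccn2)c(C(=O)N[C@@H](C)Cn2cc(-c3ccc(F)cn3)cn2)c1` has the same atoms as compound 1 joined differently; the difference between the two cores is not broken down here. In this assay compound 2 gives 840 nM, the highest number of the three measured. Compound 4 `Cc1ccc(-n2nccn2)c(C(=O)N(C)[C@@H](C)Cn2cc(-c3ccc(F)cn3)cn2)c1` is related to compound 2 by methyl in place of hydrogen on an amide-type nitrogen, the same change at the same place. The expected step is a 9.3-fold lower number from compound 2 to compound 4 (0.97 log units; beyond the scatter), resting on the size of a 10-fold lower number from compound 1 to compound 3 (1.01 log units; beyond the scatter). Going by these compounds, whether that gain carries over to the core of compound 2 is untested, so the range is wide. Compound 4 is estimated at 90 nM in this assay, between 25 nM and 320 nM.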

Compound 4, half-maximal inhibitory concentration: 21.2 nM
Compound 4: the middle estimate sits 4.2-fold (0.63 log units) above what was measured; the whole stated range lies above it.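

Methyl in place of the amide hydrogen lowers the number on both cores in this assay, with a 40-fold lower number from compound 2 to compound 4 (1.60 log units; beyond the scatter), so the direction of the change carries from the core of compound 1 to the core of compound 2. The size of the step does not carry over unchanged: the same change on two cores in this assay, a 10-fold lower number (1.01 log units; beyond the scatter) from compound 1 to compound 3 and a 40-fold lower number (1.60 log units; beyond the scatter) from compound 2 to compound 4, 3.9-fold (0.59 log units) apart, beyond the scatter of two such steps. These two pairs do not show why the steps differ in size, or whether the direction would hold on any further core.

The compounds shown carry only hydrogen or methyl on the amide nitrogen. Going by these compounds, how an ethyl or a cyclopropyl group there would read on either core stays open.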